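Shortening the butyl chain to ethyl on the amino nitrogen

The source may hold more compounds than are shown below. What is called first, only, known or untested is meant among the compounds shown, and "the series" means these compounds.

Compound 2 `CCCCN(CC)c1cc(C)nc(N(CC)c2ccc(I)cc2Br)n1` carries the highest number of the three measured compounds in an assay on isolated protein for binding affinity to corticotropin-releasing factor receptor 1 (Homo sapiens) (a higher number here means a weaker inhibitor, a lower number a stronger inhibitor), though both other compounds sit within the scatter of it: compound 2 gives 14 nM, compound 3 `CCCN(CC1CC1)c1cc(C)nc(N(CC)c2ccc(C(C)C)cc2Br)n1` gives 9 nM, and compound 1 `CCCCN(CC)c1cc(C)nc(N(CC)c2ccc(C(C)=O)cc2Br)n1` gives 8 nM. Within the data shown here, the only single-point step measured so far, a 1.8-fold higher number from compound 1 to compound 2 (0.24 log units; within the scatter), concerns the iodo in place of acetyl and stays within the scatter.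

Compound 4 `CCN(CC)c1cc(C)nc(N(CC)c2ccc(I)cc2Br)n1` differs from compound 2 by hydrogen in place of ethyl on a saturated chain carbon, two bonds along the chain from a nitrogen on an aromatic ring. Among the measured compounds shown here, no measured step touches that chain. Compound 3 differs from compound 2 in more than one place at once, so its value only shows that another substitution pattern at the amino nitrogen lands in the same region as compounds 1 and 2. The step at the acetyl-to-iodo site gives no direction for a change on the chain. The step from compound 2 to compound 4 is therefore expected to be modest, a 1.8-fold higher number from compound 2 to compound 4 (0.25 log units; within the scatter), with a slight lean toward a higher number and wide uncertainty. Compound 4 is estimated at 25 nM, with a range from 8 nM to 80 nM.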

Compound 4, inhibition constant: 9 nM
Beside the measured number, compound 4's estimate is 2.8-fold (0.44 log units) above it, within the range that was stated.
By their numbers in this assay, from the lowest: compounds 1, 3, 4 and 2 (each within the scatter of the next).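

In this assay the change from butyl(ethyl)amino to diethylamino gives a 1.6-fold lower number from compound 2 to compound 4 (0.19 log units; within the scatter) and so stays within the scatter. Among these compounds, this is the first measured step on this chain, and it shows that, with iodo on the aromatic carbon, ethyl can give way to hydrogen on a saturated chain carbon, two bonds along the chain from a nitrogen on an aromatic ring, with no difference that can be told from the scatter. No measurement at hand explains the size of this step.

Going by these compounds, the step rests on a single pair, so whether it holds with acetyl in place of iodo remains open. Also open, on these data alone, is how this position responds to a longer chain such as hexyl, or to an amine or a carboxylic acid on the chain.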